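Replacing a fluoro with pyrrolidin-1-yl on compound 3

The compounds below may be only part of what the source reports. "The series", "measured", "known", "first", "only" and "open" are said of these compounds alone.

In an ADME assay on MT4 cells (Homo sapiens) for cytotoxicity, read by MTT assay, with a stated time of 4 days (a lower number here means that less compound is tolerated, a higher number that more compound is tolerated), compound 1 (`CCCN(C)c1nc(Cc2c(F)cccc2F)cc(=O)[nH]1`) gives 85000 nM as a measured number. Compound 2 (`CCN(CC)c1nc(Cc2c(F)cccc2F)cc(=O)[nH]1`) shows > 85000 nM as a limit. Compound 3 (`O=c1cc(Cc2c(F)cccc2F)nc(N2CCCC2)[nH]1`) stands at > 86000 nM which is also a limit. Compound 4 (`O=c1cc(Cc2c(F)cccc2N2CCCC2)nc(N2CCCC2)[nH]1`) differs from compound 3 in one place (pyrrolidin-1-yl in place of fluoro on an aromatic carbon) on an aromatic carbon of a six-membered aromatic ring of carbon only. The measured steps are a number no lower from compound 1 to compound 2 (the limit leaves the size open) and an at least 1.0-fold higher number from compound 1 to compound 3 (0.00 log units; that floor lies within the scatter) and a step that the two limits leave unreadable from compound 2 to compound 3 and all three lie elsewhere, so they bear only loosely and fix no size here. In this assay the estimated step is an at least 2.1-fold lower number from compound 3 to compound 4 (0.33 log units; beyond the scatter) as a modest expected fall. Compound 4 is expected at 40000 nM with an estimated range from 12000 nM to 80000 nM overall.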

Compound 4, half-maximal cytotoxic concentration: > 73000 nM
Compound 4: only a limit was reported; the forecaster's own chance of this, stated with the estimate: 45%; at least 1.8-fold (0.26 log units) between middle value and limit.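

In this assay compound 4 gives > 73000 nM, which is a limit. Compound 3 gives > 86000 nM, also a limit, so no step can be read between compound 3 and compound 4. The compounds shown leave open whether pyrrolidin-1-yl in place of fluoro changes the tolerated concentration at all.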